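This account rests on a few compounds, and the source may have more. Where it says the series, first, only, none or still open, it means among the compounds named here.

Measured so far in an assay for inhibition of Indoleamine 2,3-dioxygenase 1 (Homo sapiens), read by spectrophotometry, with stated times of 1 h and 4 h; a higher number here means a weaker inhibitor, a lower number a stronger inhibitor:

- compound 1, `CC(=O)Nc1ccc(S(=O)(=O)NNc2ccc(F)c(Br)c2)cc1`: 128 nM
- compound 2, `CC(=O)Nc1ccc(S(=O)(=O)NNc2ccc(F)c(Cl)c2)cc1`: 110 nM
- compound 3, `CC(=O)Nc1ccc(S(=O)(=O)NNc2ccc(Br)c(F)c2)cc1`: 205 nM

Compound 1 and compound 2 share a core and differ only at one aromatic carbon, where (chloro in place of bromo on an aromatic carbon). This gives a 1.2-fold lower number from compound 1 to compound 2 (0.07 log units; within the scatter), so within this pair the exchange of the halogen leaves the result essentially where it was.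

Compound 3 carries the same atoms as compound 1, joined differently; the difference between the two cores is not broken down here. Its value in this assay sits with those of compound 1 and compound 2 inside the usual scatter, so no order among the three can be read from these numbers.

Compound 4, `CC(=O)Nc1ccc(S(=O)(=O)NNc2ccc(Cl)c(F)c2)cc1`, is not yet measured. Relative to compound 3 it has chloro in place of bromo on an aromatic carbon. Among the compounds with values here, this is the same kind of change as the one between compound 1 and compound 2, though the surroundings are not identical: in the measured pair the site is meta to a large group, whereas in compound 4 it is para to a large group. Within the data shown here, on the single precedent available, the step from compound 3 to compound 4 in this assay is expected to be small, about a 1.2-fold lower number from compound 3 to compound 4 (0.08 log units; within the scatter), because compound 1 to compound 2 showed a 1.2-fold lower number from compound 1 to compound 2 (0.07 log units; within the scatter). For compound 4 the value in this assay is therefore estimated at 170 nM, with a plausible span from 90 nM to 340 nM.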

Compound 4, half-maximal inhibitory concentration: 194 nM
Beside the measured number, compound 4's estimate is 1.1-fold (0.06 log units) below it; measured number inside the range.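

In this assay, chloro in place of bromo on an aromatic carbon gives a 1.1-fold lower number from compound 3 to compound 4 (0.02 log units; within the scatter), and this step matches the earlier one: the same change on two cores in this assay, a 1.2-fold lower number (0.07 log units; within the scatter) from compound 1 to compound 2 and a 1.1-fold lower number (0.02 log units; within the scatter) from compound 3 to compound 4, 1.1-fold (0.04 log units) apart, within the scatter of two such steps

The exchange therefore carries from the core of compound 1 to the core of compound 3 without a readable difference, and in neither core does it move the result outside the scatter, including here, where the site is ortho to a fluoro group and para to a large group. This does not show that bromo and chloro are interchangeable throughout the series, since the evidence is two pairs on closely related cores in a single assay, and steps this small can neither confirm nor exclude a slight real preference for one halogen.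

All the compounds shown carry fluoro with either bromo or chloro on this ring, so it remains open how a methoxy group, an amine, a carboxylic acid or a plain hydrogen would behave at the same site. Going by these compounds, it also remains open whether the exchange stays this small when the acetyl amide at the other end is replaced by a longer chain or a free amine.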